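The source may hold more compounds than are shown below. What is called first, only, known or untested is meant among the compounds shown, and "the series" means these compounds.

Measured so far in a functional assay on HCT-116 cells (Homo sapiens) for inhibition, read by MTT assay, with a stated time of 2 days; on this read-out lower numbers stand for stronger inhibition of growth and higher numbers for weaker inhibition of growth:
compound 1 `Nc1ccccc1NC(=O)CCCNCC(=O)Nc1cccc(Cl)c1`: 11600 nM
compound 2 `Nc1ccccc1NC(=O)CCCNCC(=O)Nc1ccc(Br)cc1`: 7700 nM
compound 3 `Nc1ccccc1NC(=O)CCCNCC(=O)Nc1cccc([N+](=O)[O-])c1`: 900 nM

Compound 3 has the lowest number of the three, and both gaps to it lie beyond the scatter: a 13-fold lower number from compound 1 to compound 3 (1.11 log units; beyond the scatter) and an 8.6-fold lower number from compound 2 to compound 3 (0.93 log units; beyond the scatter). The next compound, compound 4 `Nc1ccccc1NC(=O)CCCNCC(=O)Nc1ccccc1Cl`, has not yet been measured. The change is 2-chlorophenyl in place of 3-nitrophenyl on an amide-type nitrogen.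

Going by the values given here, no 2-chlorophenyl compound has been measured, so the nearest guides are the two steps into compound 3, together with a 1.5-fold lower number from compound 1 to compound 2 (0.18 log units; within the scatter), which stays within the scatter. Compound 4 loses the nitro group and carries a chloro group, as compound 1 does. A clear step to a higher number in this assay is therefore expected, similar in size to the two steps into compound 3 but in the opposite direction, though the data do not show how much the new chloro position matters.

The expected change is an 8.9-fold higher number from compound 3 to compound 4 (0.95 log units; beyond the scatter). For compound 4 the estimated value is 8000 nM, with an expected range of 3000 nM to 20000 nM.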

Compound 4, concentration for 50% growth inhibition: 21800 nM
Compound 4: the middle estimate sits 2.7-fold (0.44 log units) below what was measured; the whole stated range lies below it.
By their numbers in this assay, from the lowest: compound 3; then compounds 2, 1 and 4 (each within the scatter of the next, the first and the last beyond it).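

In this assay, the step of a 24-fold higher number from compound 3 to compound 4 (1.38 log units; beyond the scatter) is the largest seen so far on the amide-type nitrogen and shows that the low number of compound 3 is not kept when 2-chlorophenyl replaces 3-nitrophenyl. The comparison of the two chlorophenyl groups gives a 1.9-fold higher number from compound 1 to compound 4 (0.27 log units; within the scatter) and so shows no readable effect of moving the chloro group in this pair. Against the bromo compound, the series gives a 2.8-fold higher number from compound 2 to compound 4 (0.45 log units; beyond the scatter) and so the halogen-bearing compounds do not form one uniform set, although 3-nitrophenyl remains the only group here with a number that low, as compound 3 gives 900 nM.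

Still open, on these data alone, is whether a 2-nitrophenyl or 4-nitrophenyl group, or a nitrile or an amine on the same ring, would keep that low number. No measurement available here accounts for the gap between the nitro compound and the halogen compounds.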